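Aryl furoate esters: removing chloro from compound 3

The source may report more compounds than this note shows. Statements on the series, on what has been measured and on what is new or still open speak of the compounds shown alone.

Compound 1 `COc1cc(COC(=O)c2ccc(-c3ccccc3Cl)o2)cc(OC)c1OC`, compound 2 `COc1cc(COC(=O)c2ccc(-c3ccc(Cl)cc3Cl)o2)cc(OC)c1OC` and compound 3 `COc1cc(COC(=O)c2ccc(-c3cc(C(F)(F)F)ccc3Cl)o2)cc(OC)c1OC` share one core and differ in what sits on the six-membered aromatic ring of carbon only. In an assay on isolated protein for inhibition of high affinity 3',5'-cyclic-AMP phosphodiesterase 7A (Homo sapiens), read by scintillation proximity assay and cAMP accumulation, with a stated time of 20 min, tested at 10 uM (a higher number here means more inhibition at the concentration tested (going by the name of the read-out), a lower number less inhibition), compound 1 gives 34.6%, compound 2 gives 38.3% and compound 3 gives 8%, the lowest of the three. The change hydrogen in place of chloro on an aromatic carbon made a step of a number 3.7 percentage points lower from compound 2 to compound 1 (within the scatter); the step of a number 26.6 percentage points lower from compound 1 to compound 3 (beyond the scatter) followed from trifluoromethyl in place of hydrogen. The difference between the cores of compound 2 and compound 3 is not broken down here. Compound 4 `COc1cc(COC(=O)c2ccc(-c3cccc(C(F)(F)F)c3)o2)cc(OC)c1OC` differs from compound 3 by hydrogen in place of chloro on an aromatic carbon, the same kind of change, though here the place is ortho to a large group and para to a trifluoromethyl group rather than meta to a chloro group and para to a large group. Because the earlier step was a number 3.7 percentage points lower from compound 2 to compound 1 (within the scatter), a step of no change at the digits printed from compound 3 to compound 4 (within the scatter) is expected in this assay. Compound 4 is estimated at 8%, between -6% and 24%.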

Compound 4, a percentage reported as inhibition, at one concentration (the size of the read-out at that concentration, not a potency): 14%
Estimate against measurement, compound 4: 6 percentage points below; low and high end bracket the measured number.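

In this assay hydrogen in place of chloro gives a number 6 percentage points higher from compound 3 to compound 4 (within the scatter) and agrees with the earlier step on the other core: the same change on two cores in this assay, a number 3.7 percentage points lower (within the scatter) from compound 2 to compound 1 and a number 6 percentage points higher (within the scatter) from compound 3 to compound 4, 9.7 percentage points apart, within the scatter of two such steps. That fits this change carrying over between these two pairs, but the chloro leaves a different place in each, and two pairs give no general rule for other cores. The steps of a number 24.3 percentage points lower from compound 2 to compound 4 (beyond the scatter) and a number 20.6 percentage points lower from compound 1 to compound 4 (beyond the scatter) replace the whole aryl group with 3-(trifluoromethyl)phenyl, so they do not separate the effect of losing chloro from that of adding trifluoromethyl.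

Still open, on these data alone, is how an amine or a carboxylic acid in place of trifluoromethyl would read in this assay. Also open, as far as these compounds go, is whether an amide in place of the ester would keep the chloro step as small.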